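The source may report more compounds than this note shows. Statements on the series, on what has been measured and on what is new or still open speak of the compounds shown alone.

Measured compounds:
- compound 1 `CC(=O)Nc1nc(-c2cccc(NS(=O)(=O)c3ccc(Br)cc3)c2)cs1`: "not active" (no number reported)
- compound 2 `C#Cc1ccc(S(=O)(=O)Nc2cccc(-c3csc(NC(C)=O)n3)c2)cc1`: 59.2%

In a functional assay on A-375 cells (Homo sapiens) for antiproliferative activity, read by trypan blue exclusion, with a stated time of 48 h, tested at 1 uM (on this read-out higher numbers stand for a weaker effect at the one concentration tested and lower numbers for a stronger effect), compound 1 is reported only as "not active" (no number reported), with no number behind it. Among the compounds with values here, compound 2 is the only compound with a reported number: in this assay compound 2 gives 59.2%, so it is the sole reference point for the series, and nothing can be said about its standing relative to compound 1 beyond the fact that compound 1 carries no number.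

Compound 3 `CCCCCC/C=C\c1ccc(S(=O)(=O)Nc2cccc(-c3csc(NC(C)=O)n3)c2)cc1` is not yet measured. It differs from compound 2 by a group of 8 heavy atoms (8 carbon; no ring) in place of a group of 2 heavy atoms (2 carbon; no ring), on an aromatic carbon, an ethynyl leaving and a chain of eight carbons with one double bond entering, para to a large group. Within the data shown here, no step between measured compounds exists, so the size of the effect of this change cannot be read from the series. The estimate from compound 2 to compound 3 is a number 6.8 percentage points higher from compound 2 to compound 3 (within the scatter), a step toward a weaker effect of modest size but within a wide uncertainty. Compound 3 is expected to give 66%, in the range 35% to 95%.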

Compound 3, a percentage reported as activity, at one concentration (the size of the read-out at that concentration, not a potency): 48.8%
Estimate against measurement, compound 3: 17.2 percentage points above, and the stated range covers the measured number.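

In this assay the change from ethynyl to the chain of eight carbons with one double bond, on an aromatic carbon para to a large group, gives a number 10.4 percentage points lower from compound 2 to compound 3 (beyond the scatter) and so a stronger effect at the one concentration tested. Within the data shown here, this is the first readable step, and it shows that this position can carry the larger group with the read-out still measurable as a number. Steps involving compound 1 cannot be read, and no measured property of either group bears on the step from ethynyl to the longer chain.

The compounds shown leave open whether the stronger effect follows from chain length or from the double bond, a question that a saturated octyl chain or a shorter alkenyl chain would address. They also leave open how an amine or a carboxylic acid at this position would read.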